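Cyano on the Benzyl Ring of an Oxadiazolone Core

The compounds below may be only part of what the source reports. "The series", "measured", "known", "first", "only" and "open" are said of these compounds alone.

Measured compounds:
compound 1 `COc1nn(Cc2ccccc2)c(=O)o1`, "not active" (no number reported)
compound 2 `COc1nn(Cc2ccccc2-c2ccccc2)c(=O)o1`, 23%
compound 3 `COc1nn(Cc2ccc(NC(C)=O)cc2)c(=O)o1`, 37%

The study concerns compounds tested in an assay on COS-7 cells for inhibition of Fatty-acid amide hydrolase 1 (Homo sapiens), read by scintillation counting, with a stated time of 10 min, tested at 10 uM; on this read-out higher numbers stand for more inhibition at the one concentration tested (going by the name of the read-out) and lower numbers for less inhibition. Compound 1 `COc1nn(Cc2ccccc2)c(=O)o1` is the parent of the series and in this assay compound 1 is reported as "not active" (no number reported), with no number given, so it cannot be placed on the scale. Compound 2 `COc1nn(Cc2ccccc2-c2ccccc2)c(=O)o1` gives 23% in this assay, and compound 3 `COc1nn(Cc2ccc(NC(C)=O)cc2)c(=O)o1` gives 37%; these two values lie within the scatter of one another, so nothing separates them.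

Compound 4 `COc1nn(Cc2cccc(C#N)c2)c(=O)o1` carries a cyano group, the change from compound 1 being (cyano in place of hydrogen on an aromatic carbon). Going by the values given here, no step between measured compounds shows what this change does, and the only guide is that the two substituted analogues, compound 2 and compound 3, register modest inhibition where compound 1 registers none. A small shift upward in this assay, not clearly beyond the scatter, is therefore expected. Compound 4 is estimated to give 15% in this assay, within a range of 0% to 35%.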

Compound 4, a percentage reported as inhibition, at one concentration (the size of the read-out at that concentration, not a potency): "not active" (no number reported)
Nothing numeric was reported for compound 4, and the estimate cannot be compared.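

Going by these compounds alone, compound 1 and compound 4 are both reported as "not active", without a number, in this assay, so no step between them can be read. The compounds shown leave open whether cyano in place of hydrogen changes the inhibition in this assay at all. No supporting measurement bears on the result for compound 4.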